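The source may report more compounds than this note shows. Statements on the series, on what has been measured and on what is new or still open speak of the compounds shown alone.

Measured so far:
Compound 1, `CCCc1cccc(C[C@H](O)/C=C/[C@H]2CSC(=O)N2CCSCCCC(=O)O)c1`: > 10000 nM
Compound 2, `COCc1cccc(C[C@H](O)/C=C/[C@H]2COC(=O)N2CCSCCCC(=O)O)c1`: > 10000 nM
Compound 3, `O=C(O)CCCSCCN1C(=O)OC[C@@H]1/C=C/[C@@H](O)Cc1cccc(C(F)(F)F)c1`: > 10000 nM

All three values come from an assay on CHO cells for displacement of a labelled ligand from prostaglandin E2 receptor EP1 subtype (Mus musculus), read by scintillation counting, with a stated time of 20 min; on this read-out higher numbers stand for weaker inhibition and lower numbers for stronger inhibition. For compound 1 the value > 10000 nM is a limit of the assay and not a number. Compound 2 likewise gives only a limit, > 10000 nM. Compound 3 also stops at a limit, > 10000 nM. Compound 1 therefore stands at the limit of > 10000 nM in this assay, at which 3 of the 3 values shown sit, and nothing in the data separates it from the other two. Among the measured compounds shown here, the only step between measured compounds that differ in one place, a step that the two limits leave unreadable from compound 2 to compound 3, cannot be read either; both of its ends are limits.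

Compound 4, `CCc1cccc(C[C@H](O)/C=C/[C@H]2CSC(=O)N2CCSCCCC(=O)O)c1`, differs from compound 1 by hydrogen in place of methyl on a saturated chain carbon, two bonds along the chain from an aromatic carbon. For the measured compounds named here, no measured step involves a change of this kind, and the single measured step has no readable size, so the data give no size of step in this assay to expect from this change, in either direction. With compound 1 resting at the limit, compound 4 is expected to rest at the limit as well. The step from compound 1 to compound 4 is thus estimated as a step that the limit leaves unreadable from compound 1 to compound 4, meaning no change beyond the scatter. The estimate for compound 4 is 15000 nM, with a range from 5000 nM to 50000 nM.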

Compound 4, inhibition constant: 4600 nM
Compound 4: middle estimate off by 3.3-fold (0.51 log units), on the high side, and the stated range ends above it.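

Compound 4 gives the only value in this assay that is a number and not a limit of the assay, so this series can register on the mouse receptor at all: the limit of > 10000 nM in this assay, at which 3 of the 4 values shown sit.

Among the compounds shown here, the change from 3-propylphenyl to 3-ethylphenyl removes one methyl from the end of the chain and gives an at least 2.1-fold lower number from compound 1 to compound 4 (0.33 log units; beyond the scatter), which shows that this position responds to the loss of a single carbon, something the earlier compounds could not show. The direction is also new, since the shorter chain gives the lower number and so the stronger inhibition, although compound 4 at 4600 nM still sits close to the top of what the assay can read.

On these data alone, one end of this step is a limit, so its full size stays open, and a single pair of compounds shows no trend along the chain. As far as these compounds go, whether a 3-methylphenyl or an unsubstituted phenyl would go further in the same direction remains open, as does whether the ethyl group would do the same on the core of compound 2 or with a methoxy group in its place.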